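The source may report more compounds than this note shows. Statements on the series, on what has been measured and on what is new or still open speak of the compounds shown alone.

Of the compounds shown here, two have been tested for their effect on a line of human breast cells. Compound 1, with structure `COC(=O)C[C@H](O)[C@@H]1O[C@@H](c2ccccc2)[C@@H](O)[C@@H]1O`, carries an open ester-bearing side chain; compound 2, with structure `O=C1C=C[C@@H]2O[C@H](c3ccccc3)[C@@H](O)[C@@H]2O1`, instead closes that chain into a second ring with a carbonyl and a carbon–carbon double bond. In an ADME assay on MCF-12A cells (Homo sapiens) for cytotoxicity, read by sulforhodamine B assay, with a stated time of 48 h (a lower number here means a stronger inhibitor, a higher number a weaker inhibitor), compound 1 is reported as "not active" (no number reported), with no number given. Going by the values given here, in the same this assay compound 2 gives 120000 nM, which is the only number recorded here and points to a weak effect on these cells.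

Compound 3, with structure `O=C1C=C[C@H]2O[C@@H](c3ccccc3)[C@H](O)[C@H]2O1`, is the mirror image of compound 2: the two compounds have the same atoms and bonds and differ only in configuration as drawn: 4 of 4 stereo elements differ (all stereocentres are inverted: mirror images); a stereocentre at a saturated ring carbon is drawn S in compound 2 and R in compound 3; a stereocentre at a saturated ring carbon is drawn R in compound 2 and S in compound 3; a stereocentre at a saturated ring carbon is drawn R in compound 2 and S in compound 3; a stereocentre at a saturated ring carbon is drawn S in compound 2 and R in compound 3. Among the compounds with values here, nothing in the data shows how the mirror image of a compound behaves in this assay, so there is no measured step to lean on.

For compound 3 the expectation is a value close to that of compound 2, 120000 nM, within a range of 40000 nM to 360000 nM. The expected step from compound 2 to compound 3 in this assay is no change at the digits printed from compound 2 to compound 3 (within the scatter), which is no larger than the usual scatter.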

Compound 3, half-maximal inhibitory concentration: 110000 nM
Compound 3: middle estimate off by 1.1-fold (0.04 log units), on the high side; the range from low to high includes it.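

Going by these compounds alone, compound 3 gives the first measured step in this set, and it concerns the arrangement of the molecule in space rather than any group: in this assay, moving to the mirror image gives a 1.1-fold lower number from compound 2 to compound 3 (0.04 log units; within the scatter). The two mirror-image forms therefore cannot be told apart by these cells, so at this weak level of effect, inverting all four stereocentres together leaves no mark on the read-out. The comparison is a clean one, because nothing else separates the pair: the fact that compounds 2 and 3 differ only in the configuration as drawn.

Within the data shown here, compound 1 has no number, so no step involving it can be read, and the role of the second ring stays unsettled; the result also says nothing about which single stereocentre, if any, would matter when inverted alone, since all four are inverted at once here. From the compounds shown here alone, it remains open whether the two mirror-image forms would still match in this read-out if an amine or a carboxylic acid were attached to the shared core.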